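A few compounds are considered here, and "the series" means these few. Any claim that something is new, unique, unknown or untested is made for them only; others in the source may bear on it.

Compound 1 `CCCC(=O)Oc1ccc2oc(/C=C/[S+](C)[O-])cc(=O)c2c1` carries a propylcarbonyl ester on the oxygen on its aromatic ring, and in a functional assay on DLD-1 cells (Homo sapiens) for cytotoxicity, with a stated time of 48 h (a lower number here means a stronger inhibitor, a higher number a weaker inhibitor), compound 1 gives 8700 nM. Compound 2 `C[S+]([O-])/C=C/c1cc(=O)c2cc(O)ccc2o1` is the free hydroxy analogue. For compound 2 this assay reports only a limit, > 10000 nM, and not a number, so the step of an at least 1.1-fold higher number from compound 1 to compound 2 (0.06 log units; that floor lies within the scatter) is known only as a floor (the limit of > 10000 nM in this assay, at which 1 of the 2 values shown sits). Compound 2 thus stands at the weak end of what has been measured here, with no number of its own. Compound 3 `CCCCC(=O)Oc1ccc2oc(/C=C/[S+](C)[O-])cc(=O)c2c1` differs from compound 2 in one place: butylcarbonyl in place of hydrogen on an oxygen on an aromatic ring. Going by the values given here, the one measured step that bears on this change runs the other way, from the propylcarbonyl ester to the hydroxy compound, and gives only a floor. Reversing it with a chain one carbon longer, compound 3 is expected to return toward the ester value of compound 1, so the expected step is an at least 1.2-fold lower number from compound 2 to compound 3 (0.09 log units; that floor lies within the scatter). Compound 3 is therefore estimated at 8000 nM in this assay, within a range of 3000 nM to 20000 nM.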

Compound 3, half-maximal inhibitory concentration: 6700 nM
Compound 3: the middle estimate sits 1.2-fold (0.08 log units) above what was measured; the range from low to high includes it.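

The two esters now stand side by side at this oxygen on an aromatic ring, and they cannot be told apart: a 1.3-fold lower number from compound 1 to compound 3 (0.11 log units; within the scatter) in this assay, so methyl in place of hydrogen on the saturated chain carbon does not separate them. Against the free hydroxy compound, the second ester gives only a floor, an at least 1.4-fold lower number from compound 2 to compound 3 (0.17 log units; that floor lies within the scatter), which adds no measured size to the difference between ester and hydroxy. Compound 2 remains a limit and not a number: the limit of > 10000 nM in this assay, at which 1 of the 3 values shown sits.

As far as these compounds go, how far the hydroxy compound actually lies from the two esters stays open. So does whether a longer chain, a benzoyl ester or a carbamate on this oxygen would move the value in this assay beyond the scatter.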